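A few compounds are considered here, and "the series" means these few. Any claim that something is new, unique, unknown or untested is made for them only; others in the source may bear on it.

Measured so far in a functional assay on T47D cells (Homo sapiens) for inhibition, read by sulforhodamine B assay, with a stated time of 48 h; on this read-out lower numbers stand for stronger inhibition of growth and higher numbers for weaker inhibition of growth:

compound 1, `C=C(C/C(=C\c1ccccc1)C(=O)c1ccccc1)C(=O)c1ccccc1`, gives 15000 nM
compound 2, `C=C(C/C(=C\c1ccc(F)cc1)C(=O)c1ccccc1)C(=O)c1ccccc1`, gives 15000 nM

Compound 2 stands level with compound 1 at the digits shown: the step of no change at the digits printed from compound 1 to compound 2 (within the scatter) lies within the scatter of this assay, so the two compounds cannot be told apart on these numbers.

Compound 3, `C=C(C/C(=C\c1ccc(OC)cc1)C(=O)c1ccccc1)C(=O)c1ccccc1`, has not yet been measured in this assay. It differs from compound 2 in a single place: methoxy in place of fluoro on an aromatic carbon. Within the data shown here, the only measured step that touches this same aromatic carbon is no change at the digits printed from compound 1 to compound 2 (within the scatter), and it produced nothing beyond the scatter. Among the measured compounds shown here, no measured compound carries a methoxy group at that carbon, so there is no direct evidence for what this larger group does; the expectation can rest only on the one step that shows the ring carbon tolerating a small change without any shift in growth inhibition.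

On that basis compound 3 is expected to give about 15000 nM in this assay, with a likely range from 5000 nM to 45000 nM. For the measured compounds named here, the expected step of no change at the digits printed from compound 2 to compound 3 (within the scatter) is therefore none beyond the scatter, with the range kept wide because only a single related step is known.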

Compound 3, concentration for 50% growth inhibition: 370 nM
Compound 3: the middle estimate sits 41-fold (1.61 log units) above what was measured; the measured number lies below the stated range.
By their numbers in this assay, from the lowest: compound 3; then compounds 1 and 2 (each within the scatter of the next).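

In this assay, the aromatic carbon para to a large group proves sensitive to what it carries: methoxy in place of fluoro gives a 41-fold lower number from compound 2 to compound 3 (1.61 log units; beyond the scatter), and methoxy in place of hydrogen gives a 41-fold lower number from compound 1 to compound 3 (1.61 log units; beyond the scatter). The earlier pair, with no change at the digits printed from compound 1 to compound 2 (within the scatter), made this carbon look indifferent to substitution, but that held only for the swap of hydrogen for fluoro, and the two new steps show that a change at the same carbon can shift growth inhibition well beyond the scatter, whichever of those two groups methoxy replaces. Nothing available here explains what the methoxy group is doing at this carbon.

The compounds shown leave open which part of the methoxy group matters, since its oxygen and its carbon enter together; a hydroxyl group, a methyl group or an ethoxy group at the same carbon would begin to separate them. They also leave open whether the gain depends on this particular carbon, or whether a methoxy group on another carbon of this ring or on either of the other two aromatic rings would do the same.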